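Halogenated phenyl on the aromatic nitrogen: estimating compound 4

The source may hold more compounds than are shown below. What is called first, only, known or untested is meant among the compounds shown, and "the series" means these compounds.

Three members of the series have been run in a functional assay on HepG2 cells (Homo sapiens) for antiproliferative activity, read by MTT assay, with a stated time of 24 h; a higher number here means a weaker inhibitor, a lower number a stronger inhibitor. Compound 1 `O=c1[nH]cc(S(=O)(=O)Nc2cccc(-c3cn(-c4ccccc4F)nn3)c2)c(=O)[nH]1` gives 13900 nM. Compound 2 `O=c1[nH]cc(S(=O)(=O)Nc2cccc(-c3cn(-c4cccc(F)c4)nn3)c2)c(=O)[nH]1` is reported only as a limit of the assay, > 20000 nM. Compound 3 `O=c1[nH]cc(S(=O)(=O)Nc2cccc(-c3cn(-c4ccc(F)cc4)nn3)c2)c(=O)[nH]1` likewise returns only a limit, > 20000 nM. Moving the fluorine around the phenyl gives an at least 1.4-fold higher number from compound 1 to compound 2 (0.15 log units; that floor lies within the scatter) and an at least 1.4-fold higher number from compound 1 to compound 3 (0.15 log units; that floor lies within the scatter), while a step that the two limits leave unreadable from compound 2 to compound 3; both of those latter compounds sit at the limit of > 20000 nM in this assay, at which 2 of the 3 values shown sit, so compound 3 stands with no readable number, only the limit.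

Compound 4 `O=c1[nH]cc(S(=O)(=O)Nc2cccc(-c3cn(-c4ccccc4Cl)nn3)c2)c(=O)[nH]1` differs from compound 3 by 2-chlorophenyl in place of 4-fluorophenyl on an aromatic nitrogen. Within the data shown here, the only measured step that bears on this change is an at least 1.4-fold higher number from compound 1 to compound 3 (0.15 log units; that floor lies within the scatter), which runs the other way: the 2-substituted phenyl of compound 1 gave a readable number where the 4-fluorophenyl did not. Among the measured compounds shown here, no step covers chlorine in place of fluorine. The expectation for this assay is therefore a return toward the number of compound 1, with an at least 1.3-fold lower number from compound 3 to compound 4 (0.12 log units; that floor lies within the scatter) expected, though a second limit cannot be ruled out. Compound 4 is estimated at 15000 nM, with a range from 7000 nM to 40000 nM.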

Compound 4, half-maximal inhibitory concentration: 4030 nM
The estimate for compound 4 lay 3.7-fold (0.57 log units) above the measured number; measured number below the stated range.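

In this assay, among these compounds, chloro in place of fluoro on the same phenyl gives the first step at this position with a number at both ends: a 3.4-fold lower number from compound 1 to compound 4 (0.54 log units; beyond the scatter). With 2-chlorophenyl in place of the other two fluorophenyl groups, the steps are an at least 4.9-fold lower number from compound 3 to compound 4 (0.69 log units; beyond the scatter) and an at least 4.9-fold lower number from compound 2 to compound 4 (0.69 log units; beyond the scatter); both are floors rather than full sizes, and both lie beyond the scatter, whereas the floors of the steps from compound 1 to those same two compounds lay within it. Of the four compounds shown, only compound 1 and compound 4, with 2-fluorophenyl and 2-chlorophenyl, give a number, while compound 2 and compound 3 remain limits of the assay: the limit of > 20000 nM in this assay, at which 2 of the 4 values shown sit.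

As far as these compounds go, how 3-chlorophenyl or 4-chlorophenyl would compare with compound 4 remains open, as does whether 2-bromophenyl, 2-methylphenyl or 2-methoxyphenyl would give a lower number still. The step between compound 2 and compound 3 cannot be read, and the compounds shown do not tell why chloro gives a lower number than fluoro here.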